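Swapping the para substituent on the benzamide: methoxy variant

The source may hold more compounds than are shown below. What is called first, only, known or untested is meant among the compounds shown, and "the series" means these compounds.

Measured so far:
- compound 1 `CS(=O)(=O)c1ccc(C(=O)N2CCC(n3cncc3-c3ccc(OS(=O)(=O)c4cccc(C#N)c4)cc3)CC2)cc1` — 143 nM
- compound 2 `CN(C)c1ccc(C(=O)N2CCC(n3cncc3-c3ccc(OS(=O)(=O)c4cccc(C#N)c4)cc3)CC2)cc1` — 32 nM

Both compounds were tested in an assay on HEK293 cells for antagonist activity at P2X purinoceptor 7 (Homo sapiens), read by fluorescence, with a stated time of 2 h; a higher number here means a weaker inhibitor, a lower number a stronger inhibitor. Among the compounds with values here, compound 2 has the lowest number of the two, and its only neighbour is compound 1, which gives a higher number; that single step, a 4.5-fold lower number from compound 1 to compound 2 (0.65 log units; beyond the scatter), came from placing dimethylamino in place of methylsulfonyl on an aromatic carbon. Compound 3 `COc1ccc(C(=O)N2CCC(n3cncc3-c3ccc(OS(=O)(=O)c4cccc(C#N)c4)cc3)CC2)cc1` follows from compound 2 by a change at the same spot: methoxy in place of dimethylamino on an aromatic carbon.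

Within the data shown here, no measured pair exactly matches this swap. Among the measured compounds shown here, the one step known, from compound 1 to compound 2, shows that the group on this aromatic carbon para to a large group can move the number well beyond the scatter. Methoxy is a different group again, so compound 3 is expected to land near compound 2, perhaps somewhat higher, with the step estimated as a 1.9-fold higher number from compound 2 to compound 3 (0.27 log units; within the scatter). Compound 3 is therefore estimated at 60 nM, within a range of 25 nM to 150 nM.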

Compound 3, half-maximal inhibitory concentration: 312 nM
Compound 3: middle estimate off by 5.2-fold (0.72 log units), on the low side, and the stated range ends below it.
By their numbers in this assay, from the lowest: compound 2; then compound 1; then compound 3.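

In this assay, methoxy in place of dimethylamino on this aromatic carbon, para to a large group, gives a 9.8-fold higher number from compound 2 to compound 3 (0.99 log units; beyond the scatter) even though both groups count no hydrogen-bond donors, one hydrogen-bond acceptor and no net charge, so these shared counts do not make the two groups interchangeable here. Methoxy also compares poorly with methylsulfonyl, with a 2.2-fold higher number from compound 1 to compound 3 (0.34 log units; beyond the scatter), which leaves compound 3 the weakest of the three and shows that the earlier gain is not kept by just any small group on this carbon. Nothing available accounts for these differences.

With only three groups shown at this carbon, it remains open where a plain amino group, a methylamino group or an ethoxy group would fall. Whether the nitrogen itself matters for compound 2 also stays undecided.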